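Bromo in Place of Iodo: Expected Tolerance of Compound 4

The source may hold more compounds than are shown below. What is called first, only, known or untested is meant among the compounds shown, and "the series" means these compounds.

Of the compounds shown here, three sharing one core have been measured in an ADME assay on RAW264.7 cells (Mus musculus) for cytotoxicity, read by MTT assay, with a stated time of 18 h; a higher number here means that more compound is tolerated, a lower number that less compound is tolerated. Compound 1 `C=C1C(=O)OC[C@H]1CCOC(=O)Nc1ccc(I)cc1` gives 12800 nM, compound 2 `C=C1C(=O)OC[C@@H]1CCOC(=O)Nc1ccc(I)cc1` gives 12500 nM, and compound 3 `C=C1C(=O)OC[C@H]1CCOC(=O)Nc1ccccc1` gives 14800 nM. The step of a 1.0-fold lower number from compound 1 to compound 2 (0.01 log units; within the scatter) rests on (the fact that compounds 1 and 2 differ only in the configuration as drawn), and the step of a 1.2-fold higher number from compound 1 to compound 3 (0.06 log units; within the scatter) removes the halogen altogether. Compound 2 shows the lowest of the three numbers, yet both other compounds lie within the scatter of it. Compound 4 `C=C1C(=O)OC[C@@H]1CCOC(=O)Nc1ccc(Br)cc1` differs from compound 2 by bromo in place of iodo on an aromatic carbon. For the measured compounds named here, the only measured step at this position, a 1.2-fold higher number from compound 1 to compound 3 (0.06 log units; within the scatter), stayed within the scatter even when iodo gave way to hydrogen. The step of no change at the digits printed from compound 2 to compound 4 (within the scatter) is accordingly expected to be none beyond the scatter. Compound 4 is estimated at 12500 nM in this assay, within 7000 nM to 22000 nM.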

Compound 4, half-maximal cytotoxic concentration: 19800 nM
For compound 4 the middle estimate is 1.6-fold (0.20 log units) below the measured one; the measured number falls inside the stated range.
By their numbers in this assay, from the lowest: compounds 2, 1, 3 and 4 (each within the scatter of the next).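

Bromo in place of iodo on an aromatic carbon gives a 1.6-fold higher number from compound 2 to compound 4 (0.20 log units; within the scatter) in this assay. Until now the only replacement for iodo at this position was hydrogen, and a second halogen, in the opposite configuration as drawn, also stays within the scatter. What is known about these compounds does not bear on why bromo and iodo compare this way. On these data alone, whether an amine, a carboxylic acid or a methoxy group on this aromatic carbon would also stay within the scatter remains open. So does the outcome of bromo in the configuration of compound 1.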